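This account rests on a few compounds, and the source may have more. Where it says the series, first, only, none or still open, it means among the compounds named here.

Series notes. Compound 3 `Cc1nc(-c2ccc(Cl)cc2)sc1C(=O)CSc1nc(N)c(C#N)c(-c2ccccc2)n1` is assayed in a functional assay on MCF7 cells (Homo sapiens) for antiproliferative activity, read by MTT assay, with a stated time of 48 h (on this read-out higher numbers stand for weaker inhibition and lower numbers for stronger inhibition), where compound 3 gives 25200 nM. Compound 1 `COc1ccc(-c2nc(C)c(C(=O)CSc3nc(N)c(C#N)c(-c4ccc(OC)cc4)n3)s2)cc1` gives 24300 nM and compound 2 `Cc1nc(-c2ccccc2)sc1C(=O)CSc1nc(N)c(C#N)c(-c2ccccc2)n1` gives 30100 nM; all three numbers sit within the usual scatter of one another, so no order among them can be read. Compound 4 `COc1ccc(-c2nc(C)c(C(=O)CSc3nc(N)c(C#N)c(-c4ccccc4)n3)s2)cc1` differs from compound 3 by methoxy in place of chloro on an aromatic carbon. Within the data shown here, the only measured step touching this group, a 1.2-fold lower number from compound 2 to compound 3 (0.08 log units; within the scatter), bears on it and is small. Compound 1 also carries methoxy, and its number lies close to those of compound 2 and compound 3. Nothing here points beyond the scatter, so compound 4 is expected to stay close, with a step of a 1.0-fold lower number from compound 3 to compound 4 (0.00 log units; within the scatter). Compound 4 is therefore estimated at 25000 nM, with a range from 12000 nM to 50000 nM.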

Compound 4, half-maximal inhibitory concentration: 72100 nM
Compound 4: the middle estimate sits 2.9-fold (0.46 log units) below what was measured; measured number above the stated range.
By their numbers in this assay, from the lowest: compounds 1, 3 and 2 (each within the scatter of the next); then compound 4.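

The 4-chlorophenyl to 4-methoxyphenyl change is not silent at this position: it gives a 2.9-fold higher number from compound 3 to compound 4 (0.46 log units; beyond the scatter), and methoxy in place of hydrogen at the same carbon gives a 2.4-fold higher number from compound 2 to compound 4 (0.38 log units; beyond the scatter), whereas chloro in place of hydrogen stayed within the scatter. The outcome also depends on a second place in the molecule, with a 3.0-fold higher number from compound 1 to compound 4 (0.47 log units; beyond the scatter) on loss of the other methoxy. Compound 1, which carries methoxy at this position too, therefore goes against a general penalty for that group, and no measured evidence accounts for these steps.

Still open, on these data alone, is whether the rise belongs to methoxy alone or extends to a longer ether such as ethoxy, or to an amine at this position. Also open, as far as these compounds go, is whether the second methoxy offsets such groups as it does in compound 1.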